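Swapping 2-chlorobenzyl for 1-phenylethyl on the amide

This account rests on a few compounds, and the source may have more. Where it says the series, first, only, none or still open, it means among the compounds named here.

Three compounds measured in a physicochemical assay for lipophilicity, read by HPLC (a higher number here means a more lipophilic compound, a lower number a more polar compound), so far:
- compound 1 `Cc1ccsc1C(=CCCN(C)C(CCN)C(=O)NCc1ccccc1Cl)c1sccc1C` gives 6.11
- compound 2 `Cc1ccsc1C(=CCCN(C)C(CCO)C(=O)NCc1ccccc1)c1sccc1C` gives 5.71
- compound 3 `Cc1ccsc1C(=CCCN(C)C(CCO)C(=O)NCc1ccccc1Cl)c1sccc1C` gives 6.23

Compound 3 stands at 6.23 on this scale. Its neighbour is compound 1, with a number 0.12 log units higher from compound 1 to compound 3 (within the scatter) as the gap between them. Compound 2 lies clearly apart.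

Compound 4 `Cc1ccsc1C(=CCCN(C)C(CCO)C(=O)NC(C)c1ccccc1)c1sccc1C` has yet to be measured. The change is 1-phenylethyl in place of 2-chlorobenzyl on an amide-type nitrogen and in short it puts 1-phenylethyl in place of 2-chlorobenzyl on an amide-type nitrogen.

One measured step, a number 0.12 log units higher from compound 1 to compound 3 (within the scatter) for hydroxy in place of amino, concerns a different change and offers little guidance here. The other bears directly on it: chloro in place of hydrogen on an aromatic carbon gave a number 0.52 log units higher from compound 2 to compound 3 (beyond the scatter) and compound 4 also lacks that chloro. Yet compound 4 is not compound 2. Within the data shown here, its group on that nitrogen is 1-phenylethyl, and no measured step covers that part. It is expected to win back much of the difference, though the data do not show this.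

The expected change is a number 0.18 log units lower from compound 3 to compound 4 (within the scatter) and so a small fall that stays within the scatter. Compound 4 is thus estimated at 6.05 within a range of 5.72 to 6.38 as the likely span of the measurement.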

Compound 4, partition coefficient: 6.1
Compound 4: middle estimate off by 0.05 log units, on the low side; low and high end bracket the measured number.
By their numbers in this assay, from the lowest: compound 2; then compounds 4, 1 and 3 (each within the scatter of the next).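

In this assay, the step of a number 0.39 log units higher from compound 2 to compound 4 (beyond the scatter) puts a first measured size on adding methyl to the saturated chain carbon bound to an amide-type nitrogen and an aromatic carbon. It can be set beside the chloro step a number 0.52 log units higher from compound 2 to compound 3 (beyond the scatter), while the direct swap gives a number 0.13 log units lower from compound 3 to compound 4 (within the scatter), so on this read-out 1-phenylethyl and 2-chlorobenzyl cannot be told apart, even though the chloro sits on an aromatic carbon and the methyl on a saturated chain carbon. Nothing among the data given explains why these two different changes end up so close.

The compounds shown leave open whether the two changes add up in a single group carrying both the methyl and the chloro, and whether 1-phenylethyl and 2-chlorobenzyl would still match with amino in place of hydroxy on the chain. They also leave open how far the number moves with a longer chain on that carbon, such as 1-phenylpropyl, or with a carboxylic acid on the aromatic ring.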